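The compounds below may be only part of what the source reports. "The series", "measured", "known", "first", "only" and "open" are said of these compounds alone.

This small set covers four closely related compounds examined in an ADME assay on J774.A1 cells (Mus musculus) for cytotoxicity, read by MTT assay, with a stated time of 72 h; on this read-out lower numbers stand for an effect already at smaller amounts and higher numbers for an effect only at larger amounts of compound. Compound 1 `CC(C)Nc1nc(NCc2ccco2)c2ccc(Cl)cc2n1` carries a chloro group on its core. In this assay compound 1 reaches only a limit of the assay, > 100000 nM. Compound 3 `Cc1ccc2c(NCc3ccco3)nc(NC(C)C)nc2c1` differs from compound 1 by methyl in place of chloro on an aromatic carbon. In this assay compound 3 likewise reaches only a limit, > 33000 nM. The step that the two limits leave unreadable from compound 1 to compound 3 stays unreadable because one value sits at the limit of > 100000 nM in this assay, at which 1 of the 3 values shown sits, while the other sits at the limit of > 33000 nM in this assay, at which 2 of the 3 values shown sit.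

Compound 2 `CC(C)Nc1nc(NCc2ccco2)c2cc(Cl)ccc2n1` is built from the same atoms as compound 1, joined differently; the difference between the two cores is not broken down here. In this assay compound 2 also reaches only a limit, > 33000 nM. Compound 4 `Cc1ccc2nc(NC(C)C)nc(NCc3ccco3)c2c1` has not yet been measured; it differs from compound 2 by methyl in place of chloro on an aromatic carbon, the same change, at the same place, as that from compound 1 to compound 3.

For compound 4 the expected step is a step that the limit leaves unreadable from compound 2 to compound 4, resting on compound 3 reaching only the limit > 33000 nM. Compound 4 is therefore estimated at 60000 nM, with a range from 20000 nM to 200000 nM, and is expected most likely to be reported again only as a limit.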

Compound 4, half-maximal effective concentration: > 33000 nM
Compound 4: no number, only a limit; the forecaster's own chance of this, stated with the estimate: 85%; the middle value does not contradict the limit.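

Compound 2 and compound 4 both reach only a limit rather than a number, so no size can be given for the step between them: the limit of > 33000 nM in this assay, at which 3 of the 4 values shown sit.

The compounds shown leave open how far methyl in place of chloro on an aromatic carbon shifts the read-out in this assay, and at what concentration any of the four compounds would reach a half-maximal effect.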